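Replacing a hydroxycyclohexyl amine with an oxanyl amine

The source may hold more compounds than are shown below. What is called first, only, known or untested is meant among the compounds shown, and "the series" means these compounds.

Three compounds have been measured in an assay on isolated protein for inhibition of protein kinase C delta type (Homo sapiens), read by TR-FRET, with a stated time of 2 h; a higher number here means a weaker inhibitor, a lower number a stronger inhibitor:

compound 1 `N#Cc1cnc(NCc2cnccc2C(F)(F)F)cc1NC[C@H]1C[C@@H](O)C1`, 4200 nM
compound 2 `N#Cc1cnc(NCc2cnccc2C(F)(F)F)cc1N[C@H]1CC[C@H](O)CC1`, 6500 nM
compound 3 `N#Cc1cnc(NCc2ccccc2C(F)(F)F)cc1N[C@H]1CC[C@H](O)CC1`, recorded only as the limit > 10000 nM

Compound 2 gives the highest of the two numbers shown; compound 1 stands nearest, and the step of a 1.5-fold higher number from compound 1 to compound 2 (0.19 log units; within the scatter) is within the scatter. Compound 3 sits at the limit of > 10000 nM in this assay, at which 1 of the 3 values shown sits, a limit and not a number.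

Compound 4 `N#Cc1cnc(NCc2cnccc2C(F)(F)F)cc1NC1CCOCC1` differs from compound 2 by oxan-4-yl in place of 4-hydroxycyclohexyl on a nitrogen on an aromatic ring. Among the compounds with values here, no measured step covers this change; the only measured step, from compound 1 to compound 2, exchanged one hydroxylated ring for another and stayed within the scatter, so it offers no guide on direction. The step from compound 2 to compound 4 in this assay is therefore expected to be a 1.5-fold higher number from compound 2 to compound 4 (0.19 log units; within the scatter), with a wide range. Compound 4 is estimated at 10000 nM, between 3500 nM and 30000 nM.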

Compound 4, half-maximal inhibitory concentration: 9800 nM
Estimate against measurement, compound 4: 1.0-fold (0.01 log units) above; the measured number falls inside the stated range.
By their numbers in this assay, from the lowest: compounds 1, 2 and 4 (each within the scatter of the next, the first and the last beyond it). At a limit, above all of these: compound 3.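

In this assay, oxan-4-yl in place of 4-hydroxycyclohexyl gives a 1.5-fold higher number from compound 2 to compound 4 (0.18 log units; within the scatter) and so removes the hydrogen-bond donor of that group without a step beyond the scatter. Set against the (3-hydroxycyclobutyl)methyl group, the same oxan-4-yl gives a 2.3-fold higher number from compound 1 to compound 4 (0.37 log units; beyond the scatter) and is the first step on this nitrogen to leave the scatter, though only modestly. The compounds shown leave open whether an amine on the ring or a longer chain carrying a carboxylic acid would give a clearly lower number. Nothing measured here offers a cause for either step.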